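Ring-nitrogen substituents in the chlorophenylurea thiophene series

The compounds below may be only part of what the source reports. "The series", "measured", "known", "first", "only" and "open" are said of these compounds alone.

Measured so far in a functional assay (strain AB) with Danio rerio as the target, read by microscopy, with a stated time of 1 h; on this read-out lower numbers stand for an effect already at smaller amounts and higher numbers for an effect only at larger amounts of compound:
compound 1 `CC(C)(C)OC(=O)CCCN1CCc2c(sc(NC(=O)Nc3ccc(Cl)cc3)c2C(N)=O)C1` gives 560 nM
compound 2 `NC(=O)c1c(NC(=O)Nc2ccc(Cl)cc2)sc2c1CCN(C1CCOCC1)C2` gives 2830 nM
compound 3 `CC(C)(C)OC(=O)N1CCc2c(sc(NC(=O)Nc3ccc(Cl)cc3)c2C(N)=O)C1` gives only a limit, > 25000 nM

Compound 3 stands at the bottom of the shown numbers, since its value is a limit of the assay rather than a number (the limit of > 25000 nM in this assay, at which 1 of the 3 values shown sits). Both measured steps that lead to compound 3 are losses: an at least 44-fold higher number from compound 1 to compound 3 (1.64 log units; beyond the scatter) and an at least 8.8-fold higher number from compound 2 to compound 3 (0.94 log units; beyond the scatter). The step between the two carbon-linked substituents is smaller, a 5.1-fold higher number from compound 1 to compound 2 (0.70 log units; beyond the scatter).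

Compound 4 `NC(=O)c1c(NC(=O)Nc2ccc(Cl)cc2)sc2c1CCN(CC1CCCCC1)C2` differs from compound 3 as follows: cyclohexylmethyl in place of tert-butoxycarbonyl on an amine nitrogen in a ring. This removes the tert-butoxycarbonyl group that is shared by the two large losses and puts a carbon-linked group on the ring nitrogen, as in compound 1 and compound 2. Among the measured compounds shown here, the steps that bear on it are therefore the reversals of the losses into compound 3, one large and one at least modest, so a large step toward lower numbers in this assay is expected.

The estimate for compound 4 is 1200 nM, with a range from 300 nM to 6000 nM; the expected step is an at least 20-fold lower number from compound 3 to compound 4 (1.31 log units; beyond the scatter).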

Compound 4, half-maximal effective concentration: 1890 nM
Compound 4: middle estimate off by 1.6-fold (0.20 log units), on the low side, and the stated range covers the measured number.
By their numbers in this assay, from the lowest: compound 1; then compounds 4 and 2 (each within the scatter of the next). At a limit, above all of these: compound 3.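

In this assay, cyclohexylmethyl in place of tert-butoxycarbonyl on the amine nitrogen in the ring gives an at least 13-fold lower number from compound 3 to compound 4 (1.12 log units; beyond the scatter), a step read against a limit; as the leaving and entering groups both count 7 heavy atoms, that count alone does not separate the two compounds. Cyclohexylmethyl and oxan-4-yl are not separated either, with a 1.5-fold lower number from compound 2 to compound 4 (0.18 log units; within the scatter), so a substituent with a ring of carbon only sits level with compound 2 in this assay. Compound 1 still keeps a gap to the cyclohexylmethyl compound, with a 3.4-fold higher number from compound 1 to compound 4 (0.53 log units; beyond the scatter), and since 3-(tert-butoxycarbonyl)propyl carries the same tert-butoxycarbonyl group, the loss in this set of four goes with that group standing directly on the ring nitrogen, not with its presence as such.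

As far as these compounds go, compound 3 remains a limit and not a number, so the full size of its loss stays open: the limit of > 25000 nM in this assay, at which 1 of the 4 values shown sits. Also open, from the compounds shown here alone, is whether the gain in compound 1 rests on the chain or on its end group, which a free carboxylic acid at the chain end, a shorter or longer chain, or an amine in that place would help to settle.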